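This account rests on a few compounds, and the source may have more. Where it says the series, first, only, none or still open, it means among the compounds named here.

Working notes on the series. In an assay on isolated protein for inhibition of Indoleamine 2,3-dioxygenase 1 (Homo sapiens), read by fluorescence, with a stated time of 60 min (on this read-out higher numbers stand for weaker inhibition and lower numbers for stronger inhibition), compound 1 `CS(=O)(=O)NNc1nonc1/C(=N/O)Nc1ccc(F)c(Br)c1` gives 609 nM, compound 2 `NNc1nonc1/C(=N/O)Nc1ccc(F)c(Br)c1` gives 108 nM and compound 3 `NS(=O)(=O)NNc1nonc1/C(=N/O)Nc1ccc(F)c(Br)c1` gives 218 nM; compound 3 thus stands second of the three, with a 2.0-fold higher number from compound 2 to compound 3 (0.31 log units; beyond the scatter) and a 2.8-fold lower number from compound 1 to compound 3 (0.45 log units; beyond the scatter) around it. Compound 4 `[O-][S+]1CC(Nc2nonc2/C(=N/O)Nc2ccc(F)c(Br)c2)C1` is not yet measured. The change is a group of 5 heavy atoms (3 carbon, 1 oxygen, 1 sulfur; one four-membered non-aromatic ring with 1 hetero atom) in place of a group of 5 heavy atoms (2 nitrogen, 2 oxygen, 1 sulfur; no ring), on a nitrogen on an aromatic ring. Going by the values given here, two measured steps touch the same nitrogen: a 2.0-fold higher number from compound 2 to compound 3 (0.31 log units; beyond the scatter) and a 5.6-fold lower number from compound 1 to compound 2 (0.75 log units; beyond the scatter), both modest, and both show that a substituent on that nitrogen raises the number against the unsubstituted compound 2. Among the compounds with values here, no measured step tests a ring on that nitrogen. A modest step in this assay is therefore expected, most likely upward: compound 4 is estimated at 350 nM (range 120 nM to 1000 nM), meaning an expected step of a 1.6-fold higher number from compound 3 to compound 4 (0.21 log units; within the scatter).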

Compound 4, half-maximal inhibitory concentration: 212 nM
Estimate against measurement, compound 4: 1.7-fold (0.22 log units) above; measured number inside the range.
By their numbers in this assay, from the lowest: compounds 2, 4 and 3 (each within the scatter of the next, the first and the last beyond it); then compound 1.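

In this assay, a ring on this nitrogen on an aromatic ring is accepted: the four-membered ring carrying sulfur and oxygen replaces sulfamoylamino with a 1.0-fold lower number from compound 3 to compound 4 (0.01 log units; within the scatter), and against the bare amino group the result is a 2.0-fold higher number from compound 2 to compound 4 (0.29 log units; within the scatter), with both steps printed as within the scatter. Against the methylsulfonyl-bearing group the ring gives a 2.9-fold lower number from compound 1 to compound 4 (0.46 log units; beyond the scatter), so the gain over that group is not confined to the open sulfamoyl chain. No evidence bears on this result.

As far as these compounds go, it remains open whether the ring's sulfur and oxygen matter, as a plain cyclobutyl ring or an oxetane would test. A simple methyl or a longer alkyl chain on that nitrogen is equally unresolved.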